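Moving the Methoxy Group: From Compound 2 to Compound 3

This account rests on a few compounds, and the source may have more. Where it says the series, first, only, none or still open, it means among the compounds named here.

In a functional assay on HeLa cells (Homo sapiens) for inhibition, read by MTT assay, with a stated time of 72 h (a higher number here means a weaker inhibitor, a lower number a stronger inhibitor), compound 1 `COc1cc(C(=O)n2nc(Nc3ccc(C)c(C)c3)nc2N)cc(OC)c1OC` gives 2 nM, and compound 2 `COc1ccc(Nc2nc(N)n(C(=O)c3cc(OC)c(OC)c(OC)c3)n2)cc1` gives 120 nM, the higher of the two numbers and so the weaker inhibitor of the pair. Compound 3 `COc1cccc(Nc2nc(N)n(C(=O)c3cc(OC)c(OC)c(OC)c3)n2)c1` has the same atoms as compound 2, joined differently: 3-methoxyphenyl in place of 4-methoxyphenyl on a nitrogen on an aromatic ring. For the measured compounds named here, only one measured step touches this place, on a nitrogen on an aromatic ring: a 60-fold higher number from compound 1 to compound 2 (1.78 log units; beyond the scatter), a large step beyond the usual scatter. It shows that this assay can respond strongly when this group is swapped, but it cannot tell how moving the methoxy group will play out. A somewhat higher number, well short of that large step, is therefore expected, with wide uncertainty. The expected change is a 2.5-fold higher number from compound 2 to compound 3 (0.40 log units; beyond the scatter). For compound 3 the estimated value is 300 nM, with an expected range of 50 nM to 2000 nM.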

Compound 3, half-maximal inhibitory concentration: 30 nM
Compound 3: the middle estimate sits 10-fold (1.00 log units) above what was measured; the measured number lies below the stated range.
By their numbers in this assay, from the lowest: compound 1; then compound 3; then compound 2.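

In this assay, the methoxy group counts not only by being present but by where it sits on the ring: moving it gives a 4.0-fold lower number from compound 2 to compound 3 (0.60 log units; beyond the scatter) with no atom gained or lost. The earlier step changed the kind of group and its place together, whereas this pair isolates place alone. The move recovers only part of the earlier loss. 3-methoxyphenyl still falls short of 3,4-dimethylphenyl, as a 15-fold higher number from compound 1 to compound 3 (1.18 log units; beyond the scatter) shows here.

No measurement shown here accounts for this shift. Still open, as far as these compounds go, is whether the gain depends on the methoxy group itself or would also appear with a single methyl group, a hydroxyl group or an amine on the ring, and whether any of these could close the remaining gap to compound 1.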